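The source may report more compounds than this note shows. Statements on the series, on what has been measured and on what is new or still open speak of the compounds shown alone.

For the measured compounds named here, compound 2, `OCCc1nc(Nc2ccc(C(F)(F)F)cc2)c2ccc(-c3ncccc3C(F)(F)F)cc2n1`, gives 22 nM in a functional assay for antagonist activity at transient receptor potential cation channel subfamily V member 1 (Homo sapiens) (a lower number here means a stronger inhibitor, a higher number a weaker inhibitor), and stands at the lowest of the two numbers measured so far; compound 1, `O=C(O)COCc1nc(Nc2ccc(C(F)(F)F)cc2)c2ccc(-c3ncccc3C(F)(F)F)cc2n1`, gives 81 nM in this assay. Going by the values given here, the only measured step, a 3.7-fold lower number from compound 1 to compound 2 (0.57 log units; beyond the scatter), exchanges a carboxymethoxy for a hydroxymethyl at the end of the chain on the shared core and is the sole guide to how that chain end is tolerated. Compound 3, `OCCCc1nc(Nc2ccc(C(F)(F)F)cc2)c2ccc(-c3ncccc3C(F)(F)F)cc2n1`, carries the same chain one bond further out: hydroxymethyl in place of hydroxy on a saturated chain carbon, two bonds along the chain from an aromatic carbon. Among the compounds with values here, no measured pair addresses a lengthening of this kind. The step from compound 1 to compound 2 shows that the end of this chain can shift this assay by a modest amount, but it says nothing about the direction a longer chain ending in the same hydroxy would take. The change is therefore expected to move this assay little, with no clear direction and most likely within the scatter. Compound 3 is expected to give 30 nM in this assay, within 10 nM to 90 nM. The expected step is a 1.4-fold higher number from compound 2 to compound 3 (0.13 log units; within the scatter).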

Compound 3, half-maximal inhibitory concentration: 25 nM
The estimate for compound 3 lay 1.2-fold (0.08 log units) above the measured number; low and high end bracket the measured number.
By their numbers in this assay, from the lowest: compounds 2 and 3 (each within the scatter of the next); then compound 1.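

In this assay, a 1.1-fold higher number from compound 2 to compound 3 (0.06 log units; within the scatter) places 2-hydroxyethyl and 3-hydroxypropyl within the scatter of each other, so this chain position tolerates this lengthening without a readable change, a point the earlier pair could not address. a 3.2-fold lower number from compound 1 to compound 3 (0.51 log units; beyond the scatter) runs the same way as a 3.7-fold lower number from compound 1 to compound 2 (0.57 log units; beyond the scatter), and both steps lie beyond the scatter, so among the three compounds shown the two chains ending in hydroxy both give lower numbers than the carboxymethoxy-bearing chain of compound 1, and neither goes against this. Nothing available bears on the reason for these readings.

The compounds shown leave open whether the same flat reading holds for a longer chain ending in hydroxy, such as 4-hydroxybutyl, and whether an amine or a methyl ether at the chain end would read like the hydroxy. They also leave open how a carboxylic acid on a plain saturated chain without the ether oxygen would read, so the contributions of the acid and the ether oxygen within the chain of compound 1 cannot yet be separated.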